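The source may hold more compounds than are shown below. What is called first, only, known or untested is meant among the compounds shown, and "the series" means these compounds.

Working notes on the series. In a physicochemical assay for lipophilicity (a lower number here means a more polar compound, a higher number a more lipophilic compound), compound 1 `COc1ccc(O)c(C(=O)/C=C/c2cc(OC)c(OC)c(OC)c2)c1` gives 3.47 and compound 2 `COc1cccc(/C=C/C(=O)c2cc(OC)ccc2O)c1` gives 3.87. Compound 2 therefore holds the higher of the two numbers, and the gap to compound 1 lies beyond the scatter.

Compound 3 `COc1ccc(O)c(C(=O)/C=C/c2ccc(OC)c(OC)c2)c1` follows from compound 2 by one change, methoxy in place of hydrogen on an aromatic carbon, ortho to a methoxy group and para to a large group. Among the compounds with values here, no measured step isolates this change, so the expectation rests on two values only. With compound 1 at 3.47 and compound 2 at 3.87, a value between the two is expected in this assay. The expected change is a number 0.20 log units lower from compound 2 to compound 3 (within the scatter), a small fall probably not beyond the scatter. Compound 3 is estimated at 3.67, with an expected range of 3.4 to 3.95.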

Compound 3, partition coefficient: 3.52
The estimate for compound 3 lay 0.15 log units above the measured number, and the stated range covers the measured number.
By their numbers in this assay, from the lowest: compounds 1 and 3 (each within the scatter of the next); then compound 2.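

In this assay, the series now has a measured step for methoxy in place of hydrogen on an aromatic carbon, ortho to a methoxy group and para to a large group: a number 0.35 log units lower from compound 2 to compound 3 (beyond the scatter). The second step, hydrogen in place of methoxy on an aromatic carbon, reads a number 0.05 log units higher from compound 1 to compound 3 (within the scatter), so the same kind of change lies beyond the scatter in one pair and within it in the other. Nothing at hand bears on the reason for either step.

Going by these compounds, both steps exchange only methoxy and hydrogen, so the effect of an amine, a carboxylic acid or a longer alkoxy chain at this position remains open. With a single step at this position, the compounds shown also leave open whether the fall in compound 3 would recur on a different core.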